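Trimming the side chain of compound 2

The compounds below may be only part of what the source reports. "The series", "measured", "known", "first", "only" and "open" are said of these compounds alone.

In a functional assay on HT-29 cells (Homo sapiens) for antiproliferative activity, read by XTT assay, with a stated time of 72 h (a lower number here means a stronger inhibitor, a higher number a weaker inhibitor), compound 1 (`C=C(C)CC[C@]1(C)C2=CCC[C@](C)(C[C@H](O)c3ccoc3)[C@H]2CC[C@H]1C`) gives 30000 nM and compound 2 (`C=C(C)CCC[C@]1(C)C2=CCC[C@](C)(C[C@@H](O)C3=CC(=O)OC3O)[C@H]2CC[C@H]1C`) gives 2300 nM as the lower of the two numbers, a gap that lies beyond the usual scatter. Compound 2 is thus the stronger inhibitor of this pair, but the two structures differ in more than one place, so the gap cannot be tied to any single feature.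

Compound 3 (`C=C(C)CC[C@]1(C)C2=CCC[C@](C)(C[C@@H](O)C3=CC(=O)OC3O)[C@H]2CC[C@H]1C`) has not yet been measured. The change from compound 2 is 1-methylethenyl in place of 2-methylprop-2-en-1-yl on a saturated chain carbon, two bonds along the chain from a saturated ring carbon and it places 1-methylethenyl in place of 2-methylprop-2-en-1-yl on a saturated chain carbon, two bonds along the chain from a saturated ring carbon. Among the measured compounds shown here, no measured pair shows what this change does in this assay so any forecast here is uncertain. The change is confined to the end of one chain, and no direction can be favoured. The estimated step of a 1.1-fold higher number from compound 2 to compound 3 (0.04 log units; within the scatter) is therefore expected to stay within the scatter. Compound 3 is expected to give about 2500 nM with an estimated range from 1000 nM to 6000 nM as its likely span.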

Compound 3, half-maximal inhibitory concentration: 3600 nM
Compound 3: middle estimate off by 1.4-fold (0.16 log units), on the low side; low and high end bracket the measured number.
By their numbers in this assay, from the lowest: compounds 2 and 3 (each within the scatter of the next); then compound 1.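

In this assay, among the compounds shown here, the step of a 1.6-fold higher number from compound 2 to compound 3 (0.19 log units; within the scatter) gives the first reading of this chain end: 1-methylethenyl in place of 2-methylprop-2-en-1-yl, on a saturated chain carbon, two bonds along the chain from a saturated ring carbon, removes one carbon and leaves the numbers within the usual scatter, so this one-carbon change has no measurable effect here. Compound 3 also makes possible a comparison that compounds 1 and 2 could not offer, since it differs from compound 1 in one place only: the step of an 8.3-fold lower number from compound 1 to compound 3 (0.92 log units; beyond the scatter) lies beyond the scatter and ties a real gap to the group on the saturated chain carbon bound to a saturated ring carbon, where a five-membered non-aromatic ring with more oxygen replaces a five-membered aromatic ring. Nothing measured explains either result.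

The compounds shown leave open what a longer chain such as 4-methylpent-4-en-1-yl, or an amine or a carboxylic acid, would do at this chain end. Going by these compounds, the extra oxygen atoms and the loss of the aromatic ring also arrive together in one change, so which of them matters remains unknown.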